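Butylamino for phenoxy on the carbonyl carbon of compound 1

The source may hold more compounds than are shown below. What is called first, only, known or untested is meant among the compounds shown, and "the series" means these compounds.

Compound 1 `CN(c1ccc(NC(=O)Oc2ccccc2)cc1)c1ccnc(Nc2cccc(CS(C)(=O)=O)c2)n1` gives 224 nM in a functional assay on HUVEC cells (Homo sapiens) for inhibition; on this read-out higher numbers stand for weaker inhibition and lower numbers for stronger inhibition. Compound 2 `CN(c1ccc(NC(=O)Nc2cc(C(F)(F)F)ccc2F)cc1)c1ccnc(Nc2cccc(S(N)(=O)=O)c2)n1` gives 10 nM on the same read-out. The gap between these two numbers lies beyond the scatter, and compound 1 holds the higher of them. Compound 3 `CCCCNC(=O)Nc1ccc(N(C)c2ccnc(Nc3cccc(CS(C)(=O)=O)c3)n2)cc1` carries butylamino in place of phenoxy on a carbonyl carbon and the rest of compound 1 stays unchanged. Among the compounds with values here, no measured step covers this change, so only a modest move towards a higher number is expected, with a 1.6-fold higher number from compound 1 to compound 3 (0.19 log units; within the scatter) as the estimated step in this assay for this comparison. In this assay the estimate for compound 3 is 350 nM with an expected range from 90 nM to 1300 nM for the measurement.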

Compound 3, half-maximal inhibitory concentration: 2 nM
Beside the measured number, compound 3's estimate is 180-fold (2.24 log units) above it; the whole stated range lies above it.
By their numbers in this assay, from the lowest: compound 3; then compound 2; then compound 1.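

In this assay butylamino in place of phenoxy on a carbonyl carbon gives a 110-fold lower number from compound 1 to compound 3 (2.05 log units; beyond the scatter) with the rest of compound 1 unchanged. This position is therefore far from silent, and the six-membered aromatic ring of phenoxy is not needed here, since an open butyl chain on an amide-type nitrogen serves in its place. Nothing at hand accounts for the size of this step.

Open, as far as these compounds go, is whether the gain follows the nitrogen or the chain. Butoxy and phenylamino on the same carbonyl carbon would separate the two, and hexylamino would test a longer chain.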